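Bromo removal from compound 3 in the cytotoxicity series

The source may hold more compounds than are shown below. What is called first, only, known or untested is meant among the compounds shown, and "the series" means these compounds.

Compound 3 `O=S(=O)(Nc1cccc(CO)c1)c1ccc(-c2ccc(Br)cc2F)cc1` stands lowest of the two numbers obtained so far in a functional assay on J774 cells (Mus musculus) for cytotoxicity, read by resazurin assay, with a stated time of 72 h (a higher number here means a weaker inhibitor, a lower number a stronger inhibitor), where compound 3 gives 1000 nM. Compound 2 `O=S(=O)(Nc1cccc(CO)c1)c1ccc(-c2ccc3cc[nH]c3c2)cc1` gives 2500 nM in this assay. Compound 1 `O=S(=O)(Nc1cccc(CO)c1O)c1ccc(-c2ccc(Br)cc2)cc1` reaches only the limit > 5000 nM in this assay, a limit of the assay and not a number (the limit of > 5000 nM in this assay, at which 1 of the 3 values shown sits). Among the measured compounds shown here, the one measured step is a 2.5-fold lower number from compound 2 to compound 3 (0.40 log units; beyond the scatter), an exchange of the whole distal aryl rather than of a single substituent. Compound 4 `O=S(=O)(Nc1cccc(CO)c1)c1ccc(-c2ccccc2F)cc1` differs from compound 3 by hydrogen in place of bromo on an aromatic carbon, on an aromatic carbon of a six-membered aromatic ring of carbon only. For the measured compounds named here, no measured step removes a bromo group alone, so the expectation rests only on compound 3 at 1000 nM and the loose spread of the other numbers. A modest shift to a higher number is expected, as the step of a 2.5-fold higher number from compound 3 to compound 4 (0.40 log units; beyond the scatter). Compound 4 is therefore estimated at 2500 nM, within 1000 nM to 6000 nM, in this assay.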

Compound 4, half-maximal inhibitory concentration: 1300 nM
Compound 4: the middle estimate sits 1.9-fold (0.28 log units) above what was measured, and the stated range covers the measured number.
By their numbers in this assay, from the lowest: compounds 3, 4 and 2 (each within the scatter of the next, the first and the last beyond it). At a limit, above all of these: compound 1.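

In this assay, hydrogen in place of bromo, para to a large group, gives a step that cannot be separated from no change (a 1.3-fold higher number from compound 3 to compound 4 (0.11 log units; within the scatter)). The bromo group therefore carries no readable weight in this number at this position, and the same holds for the exchange of the whole distal aryl once the bromo is gone (a 1.9-fold lower number from compound 2 to compound 4 (0.28 log units; within the scatter)), whereas with the bromo that exchange gave a step beyond the scatter (a 2.5-fold lower number from compound 2 to compound 3 (0.40 log units; beyond the scatter)). Nothing at hand bears on the reason for this result.

Going by these compounds, whether an amine or a carboxylic acid at this place would move the number beyond the scatter stays open. On these data alone, the part played by the fluoro group on the same ring also stays open.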